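This account rests on a few compounds, and the source may have more. Where it says the series, first, only, none or still open, it means among the compounds named here.

Three compounds sharing one core were measured in a functional assay on HT-29 cells (Homo sapiens) for antiproliferative activity, read by MTT assay, with a stated time of 72 h; on this read-out lower numbers stand for stronger inhibition and higher numbers for weaker inhibition:

compound 1 `Nc1nc(N)c2cc(CSC(=S)N3CCN(C4CCCCC4)CC3)ccc2n1`: 4050 nM
compound 2 `Nc1nc(N)c2cc(CSC(=S)N3CCN(c4ccc(F)cc4)CC3)ccc2n1`: 2050 nM
compound 3 `Nc1nc(N)c2cc(CSC(=S)N3CCN(c4ccccc4[N+](=O)[O-])CC3)ccc2n1`: 4310 nM

Compound 3 stands level with one neighbour and apart from the other. The data show a 1.1-fold higher number from compound 1 to compound 3 (0.03 log units; within the scatter), so no order holds there, and a 2.1-fold higher number from compound 2 to compound 3 (0.32 log units; beyond the scatter), the only gap that counts.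

The next compound is compound 4 `Nc1nc(N)c2cc(CSC(=S)N3CCN(c4ccccn4)CC3)ccc2n1`, with pyridin-2-yl in place of 2-nitrophenyl on an amine nitrogen in a ring. Among the measured compounds shown here, no measured compound carries pyridin-2-yl, so no step speaks to this group directly. The nearest guides are the other changes at the same place, namely the two above and a 2.0-fold lower number from compound 1 to compound 2 (0.30 log units; within the scatter). None of them is large, so in this assay no step beyond the scatter is expected, with only a slight lean towards a lower number.

For compound 4 the estimated value is 3000 nM, with an expected range from 1500 nM to 6000 nM. The estimate means a 1.4-fold lower number from compound 3 to compound 4 (0.16 log units; within the scatter).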

Compound 4, half-maximal inhibitory concentration: 6200 nM
The estimate for compound 4 lay 2.1-fold (0.32 log units) below the measured number, outside the stated range (above it).
By their numbers in this assay, from the lowest: compounds 2, 1, 3 and 4 (each within the scatter of the next, the first and the last beyond it).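

In this assay, among the compounds shown here, pyridin-2-yl is the first group at this amine nitrogen whose aromatic ring holds a hetero atom, and it sets no order against 2-nitrophenyl, with a 1.4-fold higher number from compound 3 to compound 4 (0.16 log units; within the scatter), or against cyclohexyl, with a 1.5-fold higher number from compound 1 to compound 4 (0.18 log units; within the scatter). The clearest gap so far is to 4-fluorophenyl, a 3.0-fold higher number from compound 2 to compound 4 (0.48 log units; beyond the scatter), so compound 2 now stands apart from both compound 3 and compound 4, though not from compound 1, which remains within the scatter of it. Nothing available explains this gap or ties it to any feature of these groups.

The compounds shown leave open whether unsubstituted phenyl would stay with 4-fluorophenyl or with the other three groups. They also leave open how a smaller group on this nitrogen, such as methyl, or a benzyl group would compare.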